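The source may hold more compounds than are shown below. What is called first, only, known or untested is meant among the compounds shown, and "the series" means these compounds.

Three compounds share one core and differ only at a single aromatic carbon. Compound 1 `O=C1NC(=S)S/C1=C\c1ccccc1OCc1ccccc1` carries hydrogen there, compound 2 `O=C1NC(=S)S/C1=C\c1cc(Br)ccc1OCc1ccccc1` carries bromo, and compound 3 `CC(C)(C)c1ccc(OCc2ccccc2)c(/C=C2\SC(=S)NC2=O)c1` carries tert-butyl. In a functional assay on A549 cells (Homo sapiens) for inhibition, read by sulforhodamine B assay (a higher number here means a weaker inhibitor of growth, a lower number a stronger inhibitor of growth), compound 1 gives 13000 nM, compound 2 gives 7000 nM, and compound 3 gives 7000 nM. The steps between them are small: a 1.9-fold lower number from compound 1 to compound 2 (0.27 log units; within the scatter), a 1.9-fold lower number from compound 1 to compound 3 (0.27 log units; within the scatter) and no change at the digits printed from compound 2 to compound 3 (within the scatter). Compound 3 thus stands level with compound 2, the pair forming the lowest of the three numbers, with compound 1 furthest away yet still within the scatter.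

Compound 4 `COc1ccc(OCc2ccccc2)c(/C=C2\SC(=S)NC2=O)c1` is the next exchange at that carbon: methoxy in place of tert-butyl on an aromatic carbon. All three measured steps bear on it, since each swapped the group at this same carbon, and none of them moved the number beyond the scatter. A further exchange of this kind is therefore expected to leave the value essentially where it is, and the expected step is a 1.3-fold higher number from compound 3 to compound 4 (0.11 log units; within the scatter). Compound 4 is expected to give 9000 nM in this assay, within a range from 4000 nM to 20000 nM.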

Compound 4, concentration for 50% growth inhibition: 7000 nM
Compound 4: middle estimate off by 1.3-fold (0.11 log units), on the high side; the range from low to high includes it.
By their numbers in this assay, from the lowest: compounds 2, 3, 4 and 1 (each within the scatter of the next).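

In this assay, going by these compounds alone, methoxy is the only group at this carbon among the four compounds that carries oxygen, and it brings a hydrogen-bond acceptor where tert-butyl has none, yet the exchange gives no change at the digits printed from compound 3 to compound 4 (within the scatter). The comparisons with the other two groups read the same way, with no change at the digits printed from compound 2 to compound 4 (within the scatter) and a 1.9-fold lower number from compound 1 to compound 4 (0.27 log units; within the scatter), so hydrogen, bromo, tert-butyl and methoxy all lie within the scatter of one another at this carbon. No evidence is at hand that accounts for this flat reading.

The compounds shown leave open whether an amine or a carboxylic acid at this carbon would stay level with these four, or whether a longer chain in place of methoxy would. They also leave open whether exchanging the benzyloxy group, rather than the group at this carbon, would move the number beyond the scatter.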